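Notes on a fluoro-to-chloro swap in two amides

This account rests on a few compounds, and the source may have more. Where it says the series, first, only, none or still open, it means among the compounds named here.

Measured compounds:
compound 1 `O=C(NOCc1ccccc1Cl)c1cn(-c2ccccc2)nc1-c1ccccc1` gives 17800 nM in a functional assay on HeLa cells (Homo sapiens) for antiproliferative activity, read by MTT assay, with a stated time of 48 h, in the presence of a further agent that is not named here; a lower number here means a stronger inhibitor of growth, a higher number a weaker inhibitor of growth
compound 2 `COc1ccc(-c2nn(-c3ccccc3)cc2C(=O)NOCc2ccccc2F)cc1` gives 2900 nM in this assay

Compound 2 stands lowest of the two numbers in this assay; the nearest is compound 1, and the gap between them is beyond the scatter. Among the compounds with values here, the two differ in more than one place, so the numbers show only that compound 2 is the stronger inhibitor of growth, not which change carries the difference.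

Compound 3 `COc1ccc(-c2nn(-c3ccccc3)cc2C(=O)NOCc2ccccc2Cl)cc1` is not yet measured. It differs from compound 2 by chloro in place of fluoro on an aromatic carbon. Within the data shown here, no single-change step of this kind is available among the measured compounds, so the expectation rests on the change itself being small in size: the step from compound 2 to compound 3 is expected to be a 1.2-fold lower number from compound 2 to compound 3 (0.06 log units; within the scatter), not beyond the scatter in either direction. Compound 3 is estimated at 2500 nM, with a range from 900 nM to 7000 nM.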

Compound 3, concentration for 50% growth inhibition: 3480 nM
Beside the measured number, compound 3's estimate is 1.4-fold (0.14 log units) below it; the range from low to high includes it.
By their numbers in this assay, from the lowest: compounds 2 and 3 (each within the scatter of the next); then compound 1.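

In this assay the change from 2-fluorobenzyl to 2-chlorobenzyl gives a 1.2-fold higher number from compound 2 to compound 3 (0.08 log units; within the scatter) and so does not separate fluoro from chloro at this place, on an aromatic carbon ortho to a large group. With chloro held fixed, methoxy in place of hydrogen on an aromatic carbon gives a 5.1-fold lower number from compound 1 to compound 3 (0.71 log units; beyond the scatter) as a modest step, which makes it the only single change shown that lies beyond the scatter. Nothing measured here bears on the reason for either step.

Still open, from the compounds shown here alone, is whether a group other than a halogen at the fluoro and chloro place, such as trifluoromethyl, nitrile or an amine, would move the number beyond the scatter. Also open, going by these compounds, is whether the methoxy step holds with fluoro in place of chloro, and whether a hydroxyl or a carboxylic acid could stand in for methoxy.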